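Cyano in place of methylsulfonyl at the pyrrolidine chain

This account rests on a few compounds, and the source may have more. Where it says the series, first, only, none or still open, it means among the compounds named here.

Measured compounds:
Compound 1, `Cc1nn([C@H](C)c2ccc(Cl)cc2Cl)c2nc(N3CC[C@H](N4CCC[C@H]4C(N)=O)[C@H](C)C3)cnc12`: "not determined" (no result reported)
Compound 2, `Cc1nn([C@H](C)c2ccc(Cl)cc2Cl)c2nc(N3CC[C@H](N4CCC[C@H]4CCS(C)(=O)=O)[C@H](C)C3)cnc12`: "not determined" (no result reported)
Compound 3, `C[C@@H]1CC(c2cnc3c(C#N)nn([C@H](C)c4ccc(Cl)cc4Cl)c3n2)=CC[C@@H]1N1CCC[C@H]1CO`: 70 nM

In an assay on CCRF-CEM cells for antagonist activity at C-C chemokine receptor type 4 (Homo sapiens), read by CellTiter-Glo, with stated times of 30 min and 60 min, in the presence of a further agent that is not named here (on this read-out lower numbers stand for stronger inhibition and higher numbers for weaker inhibition), compound 2 has no single number; its entry reads "not determined" (no result reported), and compound 1 stands beside it as one further entry without a single number. For the measured compounds named here, compound 3, which carries a different core and a different side chain, is the only compound with a figure: in this assay compound 3 gives 70 nM. Compound 2 therefore cannot be placed against compound 3 on the numbers shown.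

Compound 4, `Cc1nn([C@H](C)c2ccc(Cl)cc2Cl)c2nc(N3CC[C@H](N4CCC[C@H]4CCC#N)[C@H](C)C3)cnc12`, is not yet measured. It differs from compound 2 in one place: cyano in place of methylsulfonyl on a saturated chain carbon, two bonds along the chain from a saturated ring carbon. The shorter form of the difference is 2-(methylsulfonyl)ethyl to 2-cyanoethyl on the pyrrolidine. Going by the values given here, no step between measured compounds carries this change, and compound 2 itself has no number, so no direction or size can be taken from the data; the step is treated as unknown rather than as none. Resting only on the figure for compound 3 in this assay, compound 4 is estimated at 100 nM, with a wide range from 20 nM to 500 nM.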

Compound 4, half-maximal inhibitory concentration: 865 nM
Beside the measured number, compound 4's estimate is 8.7-fold (0.94 log units) below it, and the stated range ends below it.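

In this assay, for the compounds shown here, compound 4 gives 865 nM, but compound 2 has no single number, so no step between the two can be read. The compounds shown leave open whether cyano or methylsulfonyl at this place gives stronger inhibition. Nothing further shown here bears on this result.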